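Trimming Isopropyl Down to Methyl

This account rests on a few compounds, and the source may have more. Where it says the series, first, only, none or still open, it means among the compounds named here.

In a functional assay for inhibition, with Rattus norvegicus as the target (on this read-out higher numbers stand for weaker inhibition and lower numbers for stronger inhibition), compound 1 (`CCC(CC)/N=c1\c(O)c(O)\c1=N/c1ccc(C#N)cc1`) gives 3340 nM and compound 2 (`CCC(C)/N=c1\c(O)c(O)\c1=N/c1ccc(C#N)cc1`) gives 2100 nM on the same scale. In the same test compound 3 (`CC(C)/N=c1\c(O)c(O)\c1=N/c1ccc(C#N)cc1`) gives 13700 nM as its reading, the highest number of the three and so the weakest inhibition among them.

Compound 4 (`C/N=c1\c(O)c(O)\c1=N/c1ccc(C#N)cc1`) carries methyl in place of isopropyl on a double-bonded nitrogen and otherwise keeps the shared core. Among the compounds with values here, no measured compound carries this methyl, so any forecast is an extrapolation. The nearest evidence is the pair of modest rises that end at the isopropyl compound: a 4.1-fold higher number from compound 1 to compound 3 (0.61 log units; beyond the scatter) and a 6.5-fold higher number from compound 2 to compound 3 (0.81 log units; beyond the scatter) both lie beyond the scatter. Trimming the chain does not always raise the number, however, since the remaining step (a 1.6-fold lower number from compound 1 to compound 2 (0.20 log units; within the scatter)) shows no rise beyond the scatter.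

On balance, a further rise of similar, modest size is expected in this assay rather than a fall. The estimated change is a 2.9-fold higher number from compound 3 to compound 4 (0.47 log units; beyond the scatter) on this reasoning. Compound 4 is expected at 40000 nM with an estimated range from 13000 nM to 130000 nM for its reading.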

Compound 4, half-maximal inhibitory concentration: > 30000 nM
Compound 4 was reported as a limit (the forecaster's own chance of this, stated with the estimate: 25%); the middle value is on the limit's open side.
By their numbers in this assay, from the lowest: compounds 2 and 1 (each within the scatter of the next); then compound 3. At a limit, above all of these: compound 4.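

In this assay compound 4 is reported only as a limit and not as a number: the limit of > 30000 nM in this assay, at which 1 of the 4 values shown sits. Even so, the step down from isopropyl to methyl on the double-bonded nitrogen can be read as an at least 2.1-fold higher number from compound 3 to compound 4 (0.34 log units; beyond the scatter), which shows that trimming this group past isopropyl still raises the number, something the earlier compounds, none of them smaller than isopropyl, could not show. Against the two larger groups the gap is wider, at an at least 14-fold higher number from compound 2 to compound 4 (1.15 log units; beyond the scatter) and an at least 8.9-fold higher number from compound 1 to compound 4 (0.95 log units; beyond the scatter), so the rise with a smaller group runs from sec-butyl through isopropyl to methyl, while pentan-3-yl and sec-butyl themselves stand within the scatter of each other and do not follow it.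

Going by these compounds, since the reading of compound 4 is a limit, the true size of these steps and how far the methyl compound lies beyond isopropyl stay open. The compounds shown also leave open how a cyclohexyl group, a benzyl group or a longer straight chain on this nitrogen would read, and so whether the number keeps falling or levels off beyond sec-butyl.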